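From hydroxy to amino: an estimate before measurement

The source may report more compounds than this note shows. Statements on the series, on what has been measured and on what is new or still open speak of the compounds shown alone.

Measured so far:
compound 1, `Nc1cccc(/C=C/c2ccccc2)c1`, gives 84 ug/mL in an ADME assay on HEK293 cells (Homo sapiens) for inhibition, read by MTT assay, with a stated time of 2 days; a lower number here means a stronger inhibitor, a higher number a weaker inhibitor.
compound 2, `COc1ccccc1/C=C/c1cccc(O)c1`, gives 24 ug/mL in this assay.

Of these two numbers, compound 2 has the lower one; its nearest neighbour, compound 1, sits higher by a gap that is beyond the usual scatter. Among the compounds with values here, compound 1 and compound 2 differ in two places at once, so no single step can be separated out between them; their values only show that compound 2 is the stronger inhibitor of the pair.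

Compound 3, `COc1ccccc1/C=C/c1cccc(N)c1`, is not yet measured. Its change from compound 2 is amino in place of hydroxy on an aromatic carbon. Within the data shown here, no measured pair here isolates this swap, so the expectation leans on compound 1, whose value 84 ug/mL is the only amino-bearing number available. For compound 3 in this assay the estimate is 42 ug/mL, with a likely range from 15 ug/mL to 110 ug/mL. That expected step, a 1.8-fold higher number from compound 2 to compound 3 (0.24 log units; within the scatter), is a modest loss of inhibition, somewhat beyond the scatter.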

Compound 3, half-maximal inhibitory concentration: 45 ug/mL
Compound 3: middle estimate off by 1.1-fold (0.03 log units), on the low side; low and high end bracket the measured number.
By their numbers in this assay, from the lowest: compounds 2, 3 and 1 (each within the scatter of the next, the first and the last beyond it).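

With the rest of the structure kept, the swap from hydroxy to amino on this aromatic carbon is a 1.9-fold higher number from compound 2 to compound 3 (0.27 log units; within the scatter) in this assay, so the two groups cannot be told apart here, even though the inhibition read-out has now been tested with both at this position. The other single change, methoxy in place of hydrogen on an aromatic carbon, is a 1.9-fold lower number from compound 1 to compound 3 (0.27 log units; within the scatter) and so also gives no clear shift on its own. Nothing measured here explains either result.

From the compounds shown here alone, whether a carboxylic acid or a longer chain such as an aminoethyl group at this position would move the number beyond the scatter remains open. Going by these compounds, it is also open whether the methoxy step would look the same with hydroxy in place of amino.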